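The compounds below may be only part of what the source reports. "The series", "measured", "known", "first", "only" and "open" are said of these compounds alone.

Measured in a functional assay on A549 cells (Homo sapiens) for cytotoxicity, read by MTT assay, with a stated time of 72 h; on this read-out higher numbers stand for weaker inhibition and lower numbers for stronger inhibition:

compound 1 `O=C(Nc1ccc(Oc2ccnc3[nH]ccc23)c(F)c1)c1cc(-c2ccc(F)cc2)ncn1` gives 14200 nM
compound 2 `O=C(Nc1ccc(Oc2ccnc3[nH]ccc23)c(F)c1)c1cc(-c2ccc(Cl)cc2)ncn1` gives 3360 nM
compound 3 `O=C(Nc1ccc(Oc2ccnc3[nH]ccc23)c(F)c1)c1cc(-c2ccc(Br)cc2)ncn1` gives 6980 nM

Compound 3 sits second highest of the three numbers. Against compound 1 the step is a 2.0-fold lower number from compound 1 to compound 3 (0.31 log units; beyond the scatter), against compound 2 it is a 2.1-fold higher number from compound 2 to compound 3 (0.32 log units; beyond the scatter); both lie beyond the scatter, so compound 3 stands between the two.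

Compound 4 `Cc1ccc(-c2cc(C(=O)Nc3ccc(Oc4ccnc5[nH]ccc45)c(F)c3)ncn2)cc1` differs from compound 3 by methyl in place of bromo on an aromatic carbon. The measured steps all swap one halogen for another on the same aromatic carbon: a 4.2-fold lower number from compound 1 to compound 2 (0.63 log units; beyond the scatter), a 2.0-fold lower number from compound 1 to compound 3 (0.31 log units; beyond the scatter) and a 2.1-fold higher number from compound 2 to compound 3 (0.32 log units; beyond the scatter), each modest. Among the compounds with values here, no measured step replaces a halogen with methyl, so the direction of the change is not fixed by the data. Since every exchange at this carbon so far moved the number only modestly, a modest step in this assay is expected for compound 4 as well, with a slight lean toward a lower number, estimated as a 1.4-fold lower number from compound 3 to compound 4 (0.14 log units; within the scatter). The expected value for compound 4 is therefore 5000 nM, within the range 1800 nM to 14000 nM.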

Compound 4, half-maximal inhibitory concentration: 8600 nM
For compound 4 the middle estimate is 1.7-fold (0.24 log units) below the measured one; the measured number falls inside the stated range.
By their numbers in this assay, from the lowest: compound 2; then compounds 3, 4 and 1 (each within the scatter of the next, the first and the last beyond it).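

Methyl, the first group at this carbon that is not a halogen, leaves the number in this assay where bromo had it, a 1.2-fold higher number from compound 3 to compound 4 (0.09 log units; within the scatter), and also shows no clear separation from fluoro, a 1.7-fold lower number from compound 1 to compound 4 (0.22 log units; within the scatter). Compound 2 stays apart from the methyl analogue, a 2.6-fold higher number from compound 2 to compound 4 (0.41 log units; beyond the scatter), so the chloro compound is the lowest of the four, and no simple halogen-versus-methyl split appears across this set. No measurement is at hand that explains why chloro stands apart from the other three groups.

From the compounds shown here alone, it remains open whether an amine, a carboxylic acid, a methoxy group or a longer chain such as butyl at this carbon would stay in the same range. The compounds shown also leave open whether the lead of chloro holds when the rest of the core of compound 2 changes.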